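The source may hold more compounds than are shown below. What is called first, only, known or untested is meant among the compounds shown, and "the series" means these compounds.

Series values in a functional assay on T-24 cells (Homo sapiens) for antiproliferative activity, read by sulforhodamine B assay, with a stated time of 72 h; a higher number here means a weaker inhibitor, a lower number a stronger inhibitor

- compound 1 `C=CCOC(=O)C1=C2C(=NC1=O)c1cccc3cccc2c13` gives 3900 nM
- compound 2 `C=CCOC(=O)C1=C2C(=NC1=O)c1cccc3c(SCCC)ccc2c13` gives 13100 nM
- compound 3 `C=CCOC(=O)C1=C2C(=NC1=O)c1cccc3c(SCC=C)ccc2c13` gives 6600 nM

Compound 2 lies at the upper end of these values, together with compound 3, and the two stay within the scatter of each other. Only a 3.4-fold higher number from compound 1 to compound 2 (0.53 log units; beyond the scatter) separates compound 2 from compound 1 beyond the scatter.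

The next entry is compound 4 `CCCSc1ccc2c3c(cccc13)C1=NC(=O)C(C(=O)OCC(=O)OCC(F)(F)C(F)(F)F)=C12`, which keeps the propylsulfanyl group of compound 2. The change is (2,2,3,3,3-pentafluoropropoxy)carbonyl in place of vinyl on a saturated chain carbon bound to an oxygen next to a carbonyl group.

The measured steps all concern the sulfur substituent: a 1.7-fold higher number from compound 1 to compound 3 (0.23 log units; within the scatter) and a 2.0-fold lower number from compound 2 to compound 3 (0.30 log units; within the scatter), alongside the step from compound 1 to compound 2 above. None touches the ester chain, so they set only a rough scale of modest steps and give no direction. In this assay no step beyond the scatter is therefore expected, and the expected step is a 1.6-fold lower number from compound 2 to compound 4 (0.21 log units; within the scatter), with wide uncertainty.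

For compound 4 the estimated value is 8000 nM, with an expected range from 2000 nM to 30000 nM.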

Compound 4, half-maximal inhibitory concentration: > 100000 nM
Compound 4: no number, only a limit; the forecaster's own chance of this, stated with the estimate: 10%; at least 12-fold (1.09 log units) between middle value and limit.
By their numbers in this assay, from the lowest: compounds 1, 3 and 2 (each within the scatter of the next, the first and the last beyond it). At a limit, above all of these: compound 4.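

In this assay compound 4 gives > 100000 nM, which is a limit and not a number. Among these compounds, this is the first step on the ester chain rather than the sulfur substituent, and with the propylsulfanyl group kept it gives an at least 7.6-fold higher number from compound 2 to compound 4 (0.88 log units; beyond the scatter), whereas the sulfur steps were modest or within the scatter. The place, a saturated chain carbon bound to an oxygen next to a carbonyl group, therefore does not tolerate every group in this assay, and the change from vinyl to (2,2,3,3,3-pentafluoropropoxy)carbonyl costs more here than any sulfur change shown.

On these data alone, the true size of this step remains open, as does whether it follows from the whole entering group or only its pentafluoropropyl end. A carboxylic acid or an amine at this place, or the same ester on the unsubstituted core of compound 1, would help separate these readings.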